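Swapping a methoxyphenyl for a carboxyphenoxy at the aryl end

The source may report more compounds than this note shows. Statements on the series, on what has been measured and on what is new or still open speak of the compounds shown alone.

Four compounds share one core and differ only in the group attached to a phenyl ring that hangs off the core. In an assay on isolated protein for agonist activity at Bile acid receptor (Homo sapiens), read by AlphaScreen, with a stated time of 30 min (on this read-out higher numbers stand for an effect only at larger amounts of compound and lower numbers for an effect already at smaller amounts), compound 1 `COC(=O)c1ccc(-c2ccc([C@H]3S[C@@H](C)C(=O)Nc4c3c(C)nn4-c3ccccc3C)cc2)cc1` is reported as "not active" (no number reported), and compound 2 `Cc1ccccc1-n1nc(C)c2c1NC(=O)[C@H](C)S[C@@H]2c1ccc(Oc2cccc(C(=O)O)c2)cc1` is likewise reported as "not active" (no number reported). For the measured compounds named here, compound 3 `COc1cccc(-c2ccc([C@H]3S[C@@H](C)C(=O)Nc4c3c(C)nn4-c3ccccc3C)cc2)c1` is therefore the only member of this set with a number in this assay, where it gives 1800 nM; it stands alone at the measured end, with the other two entries carrying no value at all.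

Compound 4 `Cc1ccccc1-n1nc(C)c2c1NC(=O)[C@H](C)S[C@@H]2c1ccc(Oc2ccc(C(=O)O)cc2)cc1` has not yet been tested. It is built from compound 3 by one replacement, (4-carboxyphenoxy in place of 3-methoxyphenyl on an aromatic carbon), so the aromatic carbon that carried the 3-methoxyphenyl now carries the 4-carboxyphenoxy.

Going by the values given here, no directly comparable pair of measured compounds exists for this step, so the expectation leans on the inactive entries. Because compound 2, which bears the related 3-carboxyphenoxy, is reported as "not active" (no number reported), the step is expected to move toward weaker activity or to leave no measurable number. The estimate for compound 4 in this assay is 4000 nM, within 1200 nM to 20000 nM, which means an expected step of a 2.2-fold higher number from compound 3 to compound 4 (0.35 log units; beyond the scatter).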

Compound 4, half-maximal effective concentration: "not active" (no number reported)
Compound 4: no number reported; no gap can be computed for the estimate.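

For the compounds shown here, compound 4, like compound 1 and compound 2, carries no number in this assay, so no step from compound 3 can be read. Nothing shown offers an explanation for this result. The compounds shown leave open whether any group other than the 3-methoxyphenyl of compound 3 gives a number on this core.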